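Amide nitrogen substituent series at the orexin receptor

The source may hold more compounds than are shown below. What is called first, only, known or untested is meant among the compounds shown, and "the series" means these compounds.

Measured so far in a functional assay on CHO cells for antagonist activity at Orexin/Hypocretin receptor type 1 (Homo sapiens), read by FLIPR and calcium flux; a lower number here means a stronger inhibitor, a higher number a weaker inhibitor:
compound 1 `Cc1cccc(C)c1NC(=O)CSc1nnc(-c2ccoc2C)n1Cc1ccco1`: compound 1 gives only a limit, > 15800 nM
compound 2 `Cc1occc1-c1nnc(SCC(=O)Nc2ccc(F)c(Cl)c2)n1Cc1ccco1`: compound 2 gives 1000 nM
compound 3 `CC(=O)c1cccc(NC(=O)CSc2nnc(-c3ccoc3C)n2Cc2ccco2)c1`: compound 3 gives 3160 nM

Compound 1 stands at the limit of the assay, (the limit of > 15800 nM in this assay, at which 1 of the 3 values shown sits), so only an upper bound on its potency is known. Within the measured set, swapping the aryl group on the amide-type nitrogen moves the number substantially: an at least 15-fold lower number from compound 1 to compound 2 (1.19 log units; beyond the scatter) and an at least 5.0-fold lower number from compound 1 to compound 3 (0.69 log units; beyond the scatter), while a 3.2-fold higher number from compound 2 to compound 3 (0.50 log units; beyond the scatter).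

Compound 4 `Cc1occc1-c1nnc(SCC(N)=O)n1Cc1ccco1` differs from compound 1 as follows: hydrogen in place of 2,6-dimethylphenyl on an amide-type nitrogen. Going by the values given here, no measured step removes the aryl group altogether, so the steps above bear on this change only in showing that the amide-type nitrogen substituent matters; they do not show what happens when the ring is gone. With compound 1 itself at a limit, the step that the limit leaves unreadable from compound 1 to compound 4 is expected to be small or not resolvable, and a limit is the likeliest outcome. For compound 4 an inhibition constant of about 25000 nM is expected, within roughly 5000 nM to 100000 nM.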

Compound 4, inhibition constant: > 15800 nM
Compound 4 gave a limit, no number (the forecaster's own chance of this, stated with the estimate: 70%); the middle value lies beyond the limit too.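

With hydrogen in place of the aryl group on the amide-type nitrogen, compound 4 reads only as a limit, as compound 1 does: the limit of > 15800 nM in this assay, at which 2 of the 4 values shown sit.

Hydrogen in place of 3-acetylphenyl gives an at least 5.0-fold higher number from compound 3 to compound 4 (0.69 log units; beyond the scatter), and hydrogen in place of 3-chloro-4-fluorophenyl gives an at least 15-fold higher number from compound 2 to compound 4 (1.19 log units; beyond the scatter), so the numbers for these two compounds depend on their aryl groups and not on the shared core alone. The step from compound 1 to compound 4 cannot be read, so 2,6-dimethylphenyl and hydrogen on that nitrogen are not told apart here.

The compounds shown leave open how an unsubstituted phenyl group would read at this position. Also open, from the compounds shown here alone, is whether a methyl group, a cyclohexyl group or a benzyl group on that nitrogen would give a number at all.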